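Bromo in place of hydrogen on the fused ring of compound 2

The source may hold more compounds than are shown below. What is called first, only, known or untested is meant among the compounds shown, and "the series" means these compounds.

Compound 2 `O=C1C(=O)N(CN(c2ccccc2)c2ccccc2)c2ccccc21` gives 23700 nM in a functional assay on MCF7 cells (Homo sapiens) for cytotoxicity, read by sulforhodamine B assay, with a stated time of 48 h (a higher number here means a weaker inhibitor of growth, a lower number a stronger inhibitor of growth), and stands alongside compound 1 `O=C1C(=O)N(CN(c2ccccc2)c2ccccc2)c2cccc(Cl)c21`, which gives 29700 nM, the two values within the scatter of each other. Compound 3 `O=C1C(=O)N(CN(c2ccccc2)c2ccccc2)c2cccc(Br)c21` carries bromo in place of hydrogen on an aromatic carbon, on an aromatic carbon of the fused system of two rings. Within the data shown here, the one step that bears on this is the exchange of chloro for hydrogen at that carbon, a 1.3-fold lower number from compound 1 to compound 2 (0.10 log units; within the scatter), within the scatter. Bromo is therefore expected to move this assay no more than the scatter, in either direction. The expected step is a 1.1-fold higher number from compound 2 to compound 3 (0.06 log units; within the scatter). Compound 3 is estimated at 27000 nM, within 12000 nM to 60000 nM.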

Compound 3, concentration for 50% growth inhibition: 110000 nM
For compound 3 the middle estimate is 4.1-fold (0.61 log units) below the measured one; the whole stated range lies below it.
By their numbers in this assay, from the lowest: compounds 2 and 1 (each within the scatter of the next); then compound 3.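

In this assay this aromatic carbon does not treat the halogens alike: bromo raises the number both in place of hydrogen (a 4.6-fold higher number from compound 2 to compound 3 (0.67 log units; beyond the scatter)) and in place of chloro (a 3.7-fold higher number from compound 1 to compound 3 (0.57 log units; beyond the scatter)). Chloro and hydrogen, by contrast, stay within the scatter of each other, so the position is not indifferent to every substituent. Nothing available here accounts for the difference between chloro and bromo.

Open, from the compounds shown here alone, is whether fluoro, iodo, methyl or an amine at this carbon would track chloro or bromo. Also open, going by these compounds, is whether bromo on another aromatic carbon of the shared core would give a similar step.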